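Changing the Amide Aryl Group in a Cell Toxicity Series

The compounds below may be only part of what the source reports. "The series", "measured", "known", "first", "only" and "open" are said of these compounds alone.

Three measured compounds share a core built around an aryl amide. Compound 1 `COc1cc2nc(C)cc(OCC(=O)Nc3cc(C)cc(C)c3)c2cc1OC` carries a 3,5-dimethylphenyl group on its amide nitrogen, and in a toxicity assay on HepG2 cells (Homo sapiens) for inhibition, read by CellTiter-Glo, with a stated time of 48 h (a lower number here means a stronger inhibitor, a higher number a weaker inhibitor), compound 1 gives 10000 nM. Compound 2 `COc1ccc2nc(C(F)(F)F)cc(OCC(=O)Nc3cc(C)cc(C)c3)c2c1` has a trifluoromethyl group on its core, and in this assay compound 2 only reaches > 100000 nM, which is a limit of the test and not a number. Compound 3 `COc1ccc2nc(C)cc(OCC(=O)Nc3ccccc3)c2c1` carries a plain phenyl group on the amide nitrogen, and in this assay compound 3 gives 39800 nM. Among the measured compounds shown here, of the two numbers obtained, compound 3 has the higher one, and the gap to compound 1 lies beyond the usual scatter; the two compounds differ in the core as well as in the aryl group, so no single step links them.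

Compound 4 `COc1ccc2nc(C)cc(OCC(=O)Nc3ccc(Br)c(C)c3)c2c1` has not yet been measured. It differs from compound 3 by 4-bromo-3-methylphenyl in place of phenyl on an amide-type nitrogen. Since compound 1, with a more substituted aryl ring, shows the lower number 10000 nM, a moderate move toward a lower number is expected, though it may stay within the scatter. Compound 4 is estimated to give 15000 nM, between 5000 nM and 50000 nM, which means an expected step of a 2.7-fold lower number from compound 3 to compound 4 (0.42 log units; beyond the scatter).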

Compound 4, half-maximal inhibitory concentration: 15900 nM
Beside the measured number, compound 4's estimate is 1.1-fold (0.03 log units) below it; low and high end bracket the measured number.
By their numbers in this assay, from the lowest: compounds 1 and 4 (each within the scatter of the next); then compound 3. At a limit, above all of these: compound 2.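

Among the compounds shown here, compound 3 and compound 4 form the first pair here that differs in one place only, so the aryl group on the amide nitrogen can now be judged on its own; the earlier compounds, which also differ in the core, did not allow this. In this assay replacing phenyl with 4-bromo-3-methylphenyl gives a 2.5-fold lower number from compound 3 to compound 4 (0.40 log units; beyond the scatter) and this modest step still lies beyond the usual scatter of repeated measurements. The number at this position therefore responds to the aryl group, and with the core held constant, a ring carrying bromine and methyl moves the compound toward stronger inhibition of the cells.

Bromine and methyl enter together, so the step cannot be divided between them, and it remains open whether either group alone would give the same shift or whether a carboxylic acid or an amine on the ring would move the number the other way. The data shown also contain no measurement that explains why this change lowers the number.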